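This account rests on a few compounds, and the source may have more. Where it says the series, first, only, none or still open, it means among the compounds named here.

Compound 1 `CCOC(=O)C1=Cc2ccccc2OC1(OCc1cn(-c2ccc(F)cc2)nn1)C(F)(F)F` gives 8900 nM in a functional assay on DU-145 cells (Homo sapiens) for inhibition, read by MTT assay, with a stated time of 24 h; a higher number here means a weaker inhibitor, a lower number a stronger inhibitor.
Compound 2 `CCOC(=O)C1=Cc2ccccc2OC1(OCc1cn(CC(=O)Nc2cccc(F)c2)nn1)C(F)(F)F` gives in this assay only a limit, > 150000 nM.
Compound 3 `CCOC(=O)C1=Cc2ccccc2OC1(OCc1cn(CC(=O)Nc2ccccc2Br)nn1)C(F)(F)F` gives in this assay only a limit, > 150000 nM.

All three share one core and differ only in the group on the aromatic nitrogen. Compound 3 thus stands at the limit of > 150000 nM in this assay, at which 2 of the 3 values shown sit, and no number can be read for it. Two steps show how far it lies from compound 1: an at least 16-fold higher number from compound 1 to compound 2 (1.22 log units; beyond the scatter) and an at least 16-fold higher number from compound 1 to compound 3 (1.22 log units; beyond the scatter). The step between the two limit compounds cannot be read: a step that the two limits leave unreadable from compound 2 to compound 3.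

Compound 4 `CCOC(=O)C1=Cc2ccccc2OC1(OCc1cn(CC(=O)Nc2ccc(C)cc2)nn1)C(F)(F)F` is not yet measured. It differs from compound 3 by 4-methylphenyl in place of 2-bromophenyl on an amide-type nitrogen. The swap on the amide-type nitrogen that is already known, from compound 2 to compound 3, left both compounds at the limit, so nothing suggests that compound 4 would move out of it. Compound 4 is therefore expected to show a number no higher from compound 3 to compound 4 (the limit leaves the size open). The estimate for compound 4 is 150000 nM, between 50000 nM and 400000 nM, with the limit itself the most likely outcome.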

Compound 4, half-maximal inhibitory concentration: > 150000 nM
Compound 4: no number, only a limit; the forecaster's own chance of this, stated with the estimate: 70%; the middle value lies on the limit itself.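

With 4-methylphenyl on the amide-type nitrogen, a ring bearing only carbon replaces the bromine- and fluorine-bearing rings, yet compound 4 is still only a limit in this assay: the limit of > 150000 nM in this assay, at which 3 of the 4 values shown sit.

Among the compounds shown, then, a halogen on this ring is not needed for a compound to sit at the limit, and the steps among compounds 2, 3 and 4 cannot be read. Set against compound 1, the ((4-methylphenyl)carbamoyl)methyl group gives an at least 16-fold higher number from compound 1 to compound 4 (1.22 log units; beyond the scatter), so this third ring on the arm also leaves the compound far weaker than compound 1.

From the compounds shown here alone, whether any group on the amide-type nitrogen can bring a readable number remains open, for example a pyridine ring or a plain ethyl chain. Also open, going by these compounds, is whether the carbamoylmethyl link or the ring it carries matters more, a question that a benzyl group on the aromatic nitrogen could help to separate.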